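Moving Away from the Weakest Benzyl Compound

The source may report more compounds than this note shows. Statements on the series, on what has been measured and on what is new or still open speak of the compounds shown alone.

- compound 1 `COc1cc(OC)c(-c2coc3cc(OCc4ccccc4F)ccc3c2=O)cc1OC` gives 1610 nM
- compound 2 `COc1cc(OC)c(-c2coc3cc(OCc4ccc(F)cc4)ccc3c2=O)cc1OC` gives 1120 nM
- compound 3 `COc1cc(OC)c(-c2coc3cc(OCc4ccccc4C(F)(F)F)ccc3c2=O)cc1OC` gives 8550 nM

These values come from a functional assay on B16 cells (Mus musculus) for antiproliferative activity, read by MTT assay, with a stated time of 24 h; a higher number here means a weaker inhibitor, a lower number a stronger inhibitor. Compound 3 has the highest number of the three and so is the weakest inhibitor here. Compound 4 `COc1cc(OC)c(-c2coc3cc(OCc4ccc(C#N)cc4)ccc3c2=O)cc1OC` has not yet been measured. On a saturated chain carbon bound to an oxygen on an aromatic ring, it carries 4-cyanophenyl in place of 2-(trifluoromethyl)phenyl (4-cyanophenyl in place of 2-(trifluoromethyl)phenyl on a saturated chain carbon bound to an oxygen on an aromatic ring).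

Among the measured compounds shown here, three measured steps bear on this change. The two that introduce 2-(trifluoromethyl)phenyl were modest and beyond the scatter: a 5.3-fold higher number from compound 1 to compound 3 (0.73 log units; beyond the scatter) and a 7.6-fold higher number from compound 2 to compound 3 (0.88 log units; beyond the scatter). The fluorine shift between the other two was small, with a 1.4-fold lower number from compound 1 to compound 2 (0.16 log units; within the scatter). Compound 2 is the closest guide, with its own 4-substituted phenyl group at 1120 nM. For the measured compounds named here, no measured compound carries 4-cyanophenyl, so the expectation remains loose. A modest move towards a lower number is expected, and the estimated step is a 4.8-fold lower number from compound 3 to compound 4 (0.68 log units; beyond the scatter). Compound 4 is estimated at 1800 nM with an expected range from 600 nM to 5500 nM as the likely span.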

Compound 4, half-maximal inhibitory concentration: 7000 nM
Beside the measured number, compound 4's estimate is 3.9-fold (0.59 log units) below it, outside the stated range (above it).
By their numbers in this assay, from the lowest: compounds 2 and 1 (each within the scatter of the next); then compounds 4 and 3 (each within the scatter of the next).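

In this assay, carrying a group at the 4 position of the phenyl ring is not enough to keep the number low: moving from 4-fluorophenyl to 4-cyanophenyl gives a 6.3-fold higher number from compound 2 to compound 4 (0.80 log units; beyond the scatter), and moving from 2-fluorophenyl to 4-cyanophenyl gives a 4.3-fold higher number from compound 1 to compound 4 (0.64 log units; beyond the scatter). The 4-cyanophenyl and 2-(trifluoromethyl)phenyl groups cannot be told apart, with a 1.2-fold lower number from compound 3 to compound 4 (0.09 log units; within the scatter), so among these four compounds only the two fluorophenyl groups give the lower numbers. Nothing available explains this difference between the groups.

The compounds shown leave open how a plain phenyl, 4-chlorophenyl or 4-methoxyphenyl group would behave at this place, and so whether the fluorophenyl groups or the other two are the exception. They also leave open what a pyridine ring or a longer chain in place of the benzyl group would give.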